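Compound 2 to compound 3: piperazine amide

A few compounds are considered here, and "the series" means these few. Any claim that something is new, unique, unknown or untested is made for them only; others in the source may bear on it.

Measured so far in a functional assay on MDA-MB-231 cells (Homo sapiens) for inhibition, read by CellTiter-Glo, with a stated time of 96 h (a lower number here means that less compound is tolerated, a higher number that more compound is tolerated), by compound:
- compound 1 `CC1=C(C(C)C(=O)NCCN(C)C)c2cc(F)ccc2/C1=C\c1ccc([S+](C)[O-])cc1` gives > 50000 nM as a limit of the assay
- compound 2 `CC1=C(C(C)C(=O)NCCN2CCCCC2)c2cc(F)ccc2/C1=C\c1ccc([S+](C)[O-])cc1` gives 39300 nM as a number

In this assay, among the measured compounds shown here, compound 2 holds the only number (39300 nM). Compound 1 gives only a limit (the limit of > 50000 nM in this assay, at which 1 of the 2 values shown sits). For the measured compounds named here, the single measured step is an at least 1.2-fold lower number from compound 1 to compound 2 (0.10 log units; that floor lies within the scatter) and it exchanges dimethylamino for piperidin-1-yl on a saturated chain carbon.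

Compound 3 `CC1=C(C(C)C(=O)N2CCN(CCN(C)C)CC2)c2cc(F)ccc2/C1=C\c1ccc([S+](C)[O-])cc1` carries its change on a carbonyl carbon, with 4-(2-(dimethylamino)ethyl)piperazin-1-yl in place of (2-(piperidin-1-yl)ethyl)amino (4-(2-(dimethylamino)ethyl)piperazin-1-yl in place of (2-(piperidin-1-yl)ethyl)amino on a carbonyl carbon). Going by the values given here, no measured step covers a change at this place, so the step from compound 1 to compound 2 bears on it only loosely. That step gives no ground for a shift beyond the scatter, and none is expected here, though the uncertainty is wide and another limit is possible.

The expected change is small (a 1.3-fold lower number from compound 2 to compound 3 (0.12 log units; within the scatter)). Compound 3 is estimated at 30000 nM (expected range 12000 nM to 50000 nM).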

Compound 3, half-maximal cytotoxic concentration: > 50000 nM
Compound 3 ended at the assay's limit (the forecaster's own chance of this, stated with the estimate: 30%); at least 1.6-fold (0.22 log units) between middle value and limit.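

In this assay compound 3 gives > 50000 nM, which is a limit of the assay and not a number. Among the compounds shown here, the first change on the carbonyl carbon, 4-(2-(dimethylamino)ethyl)piperazin-1-yl in place of (2-(piperidin-1-yl)ethyl)amino, removes the amide hydrogen and gives an at least 1.2-fold higher number from compound 2 to compound 3 (0.10 log units; that floor lies within the scatter), so the data show no shift beyond the scatter, and this exchange yields no readable number. The step from compound 1 to compound 3 cannot be read, since both values are limits, and the series now sits mostly at that ceiling: the limit of > 50000 nM in this assay, at which 2 of the 3 values shown sit.

For the compounds shown here, with compound 2 as the only compound holding a number in this assay, the size of any change at the carbonyl carbon stays unknown, as does the separate contribution of the amide hydrogen, the piperazin-1-yl unit and the dimethylamino end. A morpholin-4-yl group at the end of the chain, a piperidin-1-yl group at the end of the piperazine side chain, or a longer chain between the two nitrogens would be needed to pull these apart.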